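The source may report more compounds than this note shows. Statements on the series, on what has been measured and on what is new or still open speak of the compounds shown alone.

- Compound 1 `CCC(CCO)n1cnc2c(Cl)nc(F)nc21`: 19800 nM
- Compound 2 `CCCCCC(CCO)n1cnc2c(Cl)nc(F)nc21`: 7440 nM

In a functional assay on SW480 cells (Homo sapiens) for antiproliferative activity, read by MTT assay, with a stated time of 48 h (a lower number here means a stronger inhibitor, a higher number a weaker inhibitor), compound 2 gives 7440 nM, the lower of the two numbers and so the stronger result so far. Compound 3 `CCCCCC(CCO)n1cnc2c(Cl)nc(Cl)nc21` keeps the chain of compound 2 but has chloro in place of fluoro on an aromatic carbon, between two ring nitrogen atoms: chloro in place of fluoro on an aromatic carbon.

Within the data shown here, the only measured step, a 2.7-fold lower number from compound 1 to compound 2 (0.43 log units; beyond the scatter), came with propyl in place of hydrogen on a saturated chain carbon. It is a modest step, and it involves a different part of the molecule. Among the measured compounds shown here, no measured pair changes this halogen, so that step offers only a loose guide to size and none to direction. A small change, probably none beyond the scatter, is therefore expected in this assay. The expected step is a 1.1-fold lower number from compound 2 to compound 3 (0.06 log units; within the scatter). For compound 3 the estimated value is 6500 nM, with an expected range from 3000 nM to 15000 nM.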

Compound 3, half-maximal inhibitory concentration: 6010 nM
The estimate for compound 3 lay 1.1-fold (0.03 log units) above the measured number, and the stated range covers the measured number.
By their numbers in this assay, from the lowest: compounds 3 and 2 (each within the scatter of the next); then compound 1.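

In this assay, chloro in place of fluoro on the aromatic carbon between two ring nitrogen atoms gives a 1.2-fold lower number from compound 2 to compound 3 (0.09 log units; within the scatter), so this assay does not separate these two halogens at this position on the shared core. Among these compounds, this is the first measured information about this position, and it contrasts with the chain change, a 2.7-fold lower number from compound 1 to compound 2 (0.43 log units; beyond the scatter), which lies beyond the scatter. No measurement available here explains why the two halogens read alike.

The compounds shown leave open whether a different kind of group on this carbon, such as an amine or a methoxy group, would move the number beyond the scatter. They also leave open whether fluoro and chloro would read alike on the shorter chain of compound 1.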